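A few compounds are considered here, and "the series" means these few. Any claim that something is new, unique, unknown or untested is made for them only; others in the source may bear on it.

Within the data shown here, compound 1 `COc1ccc(S(=O)(=O)N2CCN(c3nc(N)c4cc(OC)c(OC)cc4n3)CC2)cc1` gives 39000 nM in a functional assay on PC-3 cells (Homo sapiens) for inhibition (on this read-out lower numbers stand for stronger inhibition and higher numbers for weaker inhibition), the lowest of the two numbers measured so far. Compound 2 `COc1cc2nc(N3CCN(S(=O)(=O)c4cc(F)c(Cl)c(C(=O)O)c4)CC3)nc(N)c2cc1OC` gives 56000 nM in this assay; the step of a 1.4-fold higher number from compound 1 to compound 2 (0.16 log units; within the scatter) came with 3-carboxy-4-chloro-5-fluorophenyl in place of 4-methoxyphenyl on the sulfonyl sulfur. Compound 3 `COc1cc2nc(N3CCN(S(=O)(=O)c4ccc(-c5ccc(C)cc5)cc4)CC3)nc(N)c2cc1OC` keeps the core of compound 1 and differs from it in one place: 4-methylphenyl in place of methoxy on an aromatic carbon, para to a large group. Among the measured compounds shown here, the only measured step changes the same aryl group on the sulfonyl sulfur, though with different groups, and it stayed within the scatter. Nothing measured shows what a 4-methylphenyl does at this position. The expected step of a 1.1-fold lower number from compound 1 to compound 3 (0.05 log units; within the scatter) in this assay for compound 3 is therefore one of no clear size beyond the scatter. Compound 3 is estimated at 35000 nM, with a range from 9000 nM to 130000 nM.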

Compound 3, half-maximal inhibitory concentration: 3400 nM
For compound 3 the middle estimate is 10-fold (1.01 log units) above the measured one; the whole stated range lies above it.
By their numbers in this assay, from the lowest: compound 3; then compounds 1 and 2 (each within the scatter of the next).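

Putting 4-methylphenyl in place of methoxy on this aromatic carbon, para to a large group, gives an 11-fold lower number from compound 1 to compound 3 (1.06 log units; beyond the scatter) in this assay. Among these compounds, this is the first step beyond the scatter, so this end of the aryl group on the sulfonyl sulfur can clearly change the inhibition, and here a second six-membered aromatic ring of carbon only goes with stronger inhibition than the methoxy gives. Nothing on hand explains why the number falls.

From the compounds shown here alone, it remains open whether the ring alone carries this effect or whether its methyl also contributes, which a plain phenyl at the same place would help to show. Going by these compounds, it is equally open whether a longer alkyl chain, an amine or a carboxylic acid on the outer ring would keep the lower number.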